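Working notes: cytotoxicity across the shared core

The source may report more compounds than this note shows. Statements on the series, on what has been measured and on what is new or still open speak of the compounds shown alone.

In an ADME assay on MOLT-3 cells (Homo sapiens) for cytotoxicity, with a stated time of 7 days (on this read-out higher numbers stand for lower toxicity in this test and lower numbers for higher toxicity in this test), compound 1 `CCCCSc1nc(N)nc2c1ncn2/C=C1/CC1(CO)CO` gives only a limit, > 20000 nM. Compound 2 `Nc1nc(NC2CC2)c2ncn(/C=C3/CC3(CO)CO)c2n1` likewise reaches only a limit, > 20000 nM. The move a step that the two limits leave unreadable from compound 1 to compound 2 is therefore unreadable, as both ends sit at the limit of > 20000 nM in this assay, at which 2 of the 3 values shown sit. Compound 3 `CC(C)CNc1nc(N)nc2c1ncn2/C=C1/CC1(CO)CO` has no result in this assay, "not determined" (no result reported), and so offers no number of its own.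

Compound 4 `Nc1nc(OCC(F)(F)F)c2ncn(/C=C3/CC3(CO)CO)c2n1` differs from compound 3 by 2,2,2-trifluoroethoxy in place of isobutylamino on an aromatic carbon. Among the compounds with values here, no measured step bears on this change; the only comparison available is unreadable. Both readable entries in the series are limits, so no direction can be drawn.

For compound 4 the expected value in this assay is 25000 nM, estimated to lie between 8000 nM and 60000 nM.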

Compound 4, half-maximal cytotoxic concentration: > 20000 nM
Compound 4 ended at the assay's limit; the forecaster's own chance of this, stated with the estimate: 75%; the middle value is on the limit's open side.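

The steps from compound 1 and from compound 2 to compound 4 cannot be read, because all three compounds end at a limit: the limit of > 20000 nM in this assay, at which 3 of the 4 values shown sit. The compounds shown leave open whether the groups on this aromatic carbon differ at all in this assay.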